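The source may report more compounds than this note shows. Statements on the series, on what has been measured and on what is new or still open speak of the compounds shown alone.

Measured so far:
- compound 1, `Cc1cc(C)c(S(C)(=O)=O)cc1C(=O)N=C(N)N`, in a functional assay for inhibition of sodium/hydrogen exchanger (Oryctolagus cuniculus) (on this read-out lower numbers stand for stronger inhibition and higher numbers for weaker inhibition), gives 11 nM
- compound 2, `Cc1cc(OC2CCCC2)c(S(C)(=O)=O)cc1C(=O)N=C(N)N`, in this assay gives 27 nM
- compound 3, `Cc1cc(Oc2ccccc2Cl)c(S(C)(=O)=O)cc1C(=O)N=C(N)N`, in this assay gives 14 nM

All three share one core and differ only in the group on one aromatic carbon. Compound 3 sits close to both neighbours: the change is a 1.3-fold higher number from compound 1 to compound 3 (0.10 log units; within the scatter) and a 1.9-fold lower number from compound 2 to compound 3 (0.29 log units; within the scatter), so neither gap is more than ordinary measurement noise. Only the move to a cyclopentyloxy group stands out, with a 2.5-fold higher number from compound 1 to compound 2 (0.39 log units; beyond the scatter).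

Compound 4, `Cc1cn(-c2cc(C)c(C(=O)N=C(N)N)cc2S(C)(=O)=O)cn1`, changes the same position: 4-methyl-1H-imidazol-1-yl in place of 2-chlorophenoxy on an aromatic carbon. The three known steps at this spot all stayed modest or within the scatter, which suggests the position accepts quite different groups without a large effect. A small aromatic ring with two nitrogens is new here, so some caution is warranted, but the expectation for this assay is a step of a 1.4-fold higher number from compound 3 to compound 4 (0.15 log units; within the scatter), essentially flat. Compound 4 is therefore estimated at 20 nM, with a range from 7 nM to 60 nM.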

Compound 4, half-maximal inhibitory concentration: 28 nM
For compound 4 the middle estimate is 1.4-fold (0.15 log units) below the measured one, and the stated range covers the measured number.
By their numbers in this assay, from the lowest: compounds 1, 3, 2 and 4 (each within the scatter of the next, the first and the last beyond it).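

In this assay, a five-membered aromatic ring with two nitrogens is accepted on this aromatic carbon about as well as the two larger oxygen-linked groups: the swaps for 2-chlorophenoxy (a 2.0-fold higher number from compound 3 to compound 4 (0.30 log units; within the scatter)) and cyclopentyloxy (a 1.0-fold higher number from compound 2 to compound 4 (0.02 log units; within the scatter)) both stay within the scatter. The swap for methyl is modest but real (a 2.5-fold higher number from compound 1 to compound 4 (0.41 log units; beyond the scatter)), so cyclopentyloxy and 4-methyl-1H-imidazol-1-yl are the two groups here that differ measurably from methyl, while 2-chlorophenoxy does not. No measured evidence is available to explain these differences.

The compounds shown leave open how an amine, a carboxylic acid or a longer alkyl chain would fare on this carbon. They also leave open whether a pyridine ring or an unsubstituted imidazole would give a similar number.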